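The source may report more compounds than this note shows. Statements on the series, on what has been measured and on what is new or still open speak of the compounds shown alone.

Measured compounds in this study:

Compound 1 `C=C(C)[C@@H]1CC=C(Cn2cc(COc3ccc(C4NC(=O)NC(C)=C4C(C)=O)cc3)nn2)CC1`: in a functional assay on NCI/ADR-RES cells (Homo sapiens) for inhibition, read by sulforhodamine B assay, with a stated time of 48 h (on this read-out higher numbers stand for weaker inhibition of growth and lower numbers for stronger inhibition of growth), compound 1 reaches only the limit > 100000 nM.
Compound 2 `C=C(C)[C@@H]1CC=C(Cn2cc(COc3ccc(C4NC(=O)NC(C)=C4C(C)=O)cc3OC)nn2)CC1`: in this assay compound 2 gives 80200 nM.
Compound 3 `C=C(C)[C@@H]1CC=C(Cn2cc(COc3cccc(C4NC(=O)NC5=C4C(=O)CC(C)(C)C5)c3)nn2)CC1`: in this assay compound 3 reaches only the limit > 100000 nM.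

Compound 1 and compound 2 share a core and differ by one change, (methoxy in place of hydrogen on an aromatic carbon). That change made a step of an at least 1.2-fold lower number from compound 1 to compound 2 (0.09 log units; that floor lies within the scatter), and since the value of compound 1 is a limit, the step itself is only a floor. Two of the three values sit at the same limit, (the limit of > 100000 nM in this assay, at which 2 of the 3 values shown sit), so most of this set is unresolved in this assay.

Compound 3 carries a different core from compound 1; the difference between the two cores is not broken down here. Compound 4 `C=C(C)[C@@H]1CC=C(Cn2cc(COc3cc(C4NC(=O)NC5=C4C(=O)CC(C)(C)C5)ccc3OC)nn2)CC1` is not yet measured and differs from compound 3 by methoxy in place of hydrogen on an aromatic carbon. This is the same kind of change as from compound 1 to compound 2, though the place is not identical: in compound 2 the methoxy sits meta to a large group, in compound 4 para to a large group.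

Going by the values given here, on the one step seen, the move from compound 3 to compound 4 is expected to be small, an at least 1.1-fold lower number from compound 3 to compound 4 (0.04 log units; that floor lies within the scatter), because compound 1 to compound 2 gave only an at least 1.2-fold lower number from compound 1 to compound 2 (0.09 log units; that floor lies within the scatter). Compound 4 is therefore estimated at 90000 nM in this assay, with a fair chance that only a limit is reported again.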

Compound 4, concentration for total growth inhibition: > 100000 nM
Compound 4 was reported as a limit; the forecaster's own chance of this, stated with the estimate: 60%; middle value at least 1.1-fold (0.04 log units) away from the limit.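

Compound 3 and compound 4 both stand only at a limit in this assay, so no step can be read between them. What methoxy in place of hydrogen on an aromatic carbon does on the core of compound 3 stays open, as does any order among the compounds held at the limit: the limit of > 100000 nM in this assay, at which 3 of the 4 values shown sit.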